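Changing the group on the aromatic amine nitrogen

A few compounds are considered here, and "the series" means these few. Any claim that something is new, unique, unknown or untested is made for them only; others in the source may bear on it.

In an assay on FRT-Jurkat cells for inhibition of nuclear factor NF-kappa-B complex (Homo sapiens), read by flow cytometry, with a stated time of 24 h, tested at 10 uM (a lower number here means less inhibition, a higher number more inhibition at the concentration tested (going by the name of the read-out)), compound 1 `O=C1CCC(N2C(=O)c3ccc(Nc4ccc(O)cc4)cc3C2=O)C(=O)N1` gives 4%, compound 2 `O=C1CCC(N2C(=O)c3ccc(Nc4ccccn4)cc3C2=O)C(=O)N1` gives 9% and compound 3 `Cc1ccccc1Nc1cccc2c1C(=O)N(C1CCC(=O)NC1=O)C2=O` gives 7%. Compound 3 stands second highest of the three numbers shown, but its gaps to compound 2 and to compound 1 both lie within the scatter. Compound 4 `CC(=O)c1ccc(Nc2cccc3c2C(=O)N(C2CCC(=O)NC2=O)C3=O)cc1` differs from compound 3 in one place: 4-acetylphenyl in place of 2-methylphenyl on a nitrogen on an aromatic ring. For the measured compounds named here, the only measured step on that same nitrogen, a number 5 percentage points higher from compound 1 to compound 2 (within the scatter), also exchanged the group there and stayed within the scatter. Nothing shown points to a step beyond the scatter for this exchange, so compound 4 is expected to give 7%, between 0% and 18%. The expected step is no change at the digits printed from compound 3 to compound 4 (within the scatter).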

Compound 4, a percentage reported as inhibition, at one concentration (the size of the read-out at that concentration, not a potency): 2%
Compound 4: middle estimate off by 5 percentage points, on the high side; the measured number falls inside the stated range.
By their numbers in this assay, from the lowest: compounds 4, 1, 3 and 2 (each within the scatter of the next).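

In this assay, putting 4-acetylphenyl in place of 2-methylphenyl on this nitrogen gives a number 5 percentage points lower from compound 3 to compound 4 (within the scatter). This exchange brings in a hydrogen-bond acceptor and a double bond outside aromatic rings, which the group it replaces lacks, and the number still stays within the scatter. Nothing shown accounts for the size of this step. From the compounds shown here alone, whether a group carrying an amine or a carboxylic acid on this nitrogen would give a step beyond the scatter remains open.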